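This account rests on a few compounds, and the source may have more. Where it says the series, first, only, none or still open, it means among the compounds named here.

Among the compounds with values here, in a functional assay on Jurkat cells (Homo sapiens) for antiproliferative activity, read by MTT assay, with a stated time of 72 h (a lower number here means a stronger inhibitor, a higher number a weaker inhibitor), compound 1 `COc1cc(C(=O)c2sc3ccccc3c2-c2ccccc2)cc(OC)c1OC` gives 1500 nM and compound 2 `COc1cc(C(=O)c2sc3ccccc3c2-c2ccc(F)cc2)cc(OC)c1OC` gives 2300 nM, so compound 2 stands within the scatter of its only neighbour. Compound 3 `COc1cc(C(=O)c2sc3ccccc3c2-c2ccc(Cl)cc2)cc(OC)c1OC` differs from compound 2 by chloro in place of fluoro on an aromatic carbon. Within the data shown here, the only measured step at that same carbon, fluoro in place of hydrogen, was a 1.5-fold higher number from compound 1 to compound 2 (0.19 log units; within the scatter). No swap of one halogen for another has been measured yet. The expected step in this assay is therefore a 1.0-fold lower number from compound 2 to compound 3 (0.02 log units; within the scatter), nothing beyond the scatter. For compound 3 the estimated value is 2200 nM, with an expected range of 1000 nM to 4500 nM.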

Compound 3, half-maximal inhibitory concentration: 3700 nM
The estimate for compound 3 lay 1.7-fold (0.23 log units) below the measured number, and the stated range covers the measured number.
By their numbers in this assay, from the lowest: compounds 1, 2 and 3 (each within the scatter of the next, the first and the last beyond it).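

In this assay, the swap of one halogen for another gives a 1.6-fold higher number from compound 2 to compound 3 (0.21 log units; within the scatter) and so does not separate chloro from fluoro at this position. Set against hydrogen, chloro gives a 2.5-fold higher number from compound 1 to compound 3 (0.39 log units; beyond the scatter) and is the first change at this carbon to pass the usual scatter, though only modestly and towards a weaker inhibitor. Nothing available explains this step.

Going by these compounds, whether any group here can give a lower number than compound 1 stays open. An amine or a carboxylic acid in place of the halogen would test this.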